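A few compounds are considered here, and "the series" means these few. Any claim that something is new, unique, unknown or untested is made for them only; others in the source may bear on it.

Measured compounds, binding to an assay on isolated protein for binding affinity to adenosine receptor A1 (Bos taurus); on this read-out higher numbers stand for weaker inhibition and lower numbers for stronger inhibition:
- compound 1 `CNc1nc(-c2ccccc2)nc2c1nnn2Cc1ccccc1Cl`: 191000000 nM
- compound 2 `CC(O)CNc1nc(-c2ccccc2)nc2c1nnn2Cc1ccccc1F`: 4800000 nM
- compound 3 `CCCCCCNc1nc(-c2ccccc2)nc2c1nnn2Cc1ccccc1F`: 25000000 nM

Compound 1 gives the highest number of the three in this assay; compound 3 gives the nearest value and compound 2 the lowest, with both gaps beyond the scatter. Compound 1 and compound 3 differ in more than one place, so their values are compared only as they stand.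

Compound 4 `Clc1ccccc1Cn1nnc2c(NC3CC3)nc(-c3ccccc3)nc21` is the next member and is not yet measured in this assay. Against compound 1 the change is cyclopropyl in place of methyl on a nitrogen on an aromatic ring.

Among the compounds with values here, the only single-point step measured is a 5.2-fold higher number from compound 2 to compound 3 (0.72 log units; beyond the scatter), which concerns a chain carbon bound to the nitrogen, not the group on the nitrogen itself, and does not involve a ring. Within the data shown here, it therefore bears only loosely on the methyl to cyclopropyl exchange in compound 4; no measured pair tests a small ring at this position. The larger amine substituents of compound 2 and compound 3 both sit at lower numbers than the methylamino compound 1, but those compounds also carry a different halogen on the benzyl ring.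

On that thin basis compound 4 is expected at 60000000 nM, range 10000000 nM to 400000000 nM, a step of a 3.2-fold lower number from compound 1 to compound 4 (0.50 log units; beyond the scatter).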

Compound 4, inhibition constant: 11000000 nM
The estimate for compound 4 lay 5.5-fold (0.74 log units) above the measured number, and the stated range covers the measured number.
By their numbers in this assay, from the lowest: compound 2; then compound 4; then compound 3; then compound 1.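

In this assay the group on the nitrogen on an aromatic ring is now tested directly, with everything else held constant, and the exchange gives a 17-fold lower number from compound 1 to compound 4 (1.24 log units; beyond the scatter). Within the data shown here, the only earlier single-point step, a 5.2-fold higher number from compound 2 to compound 3 (0.72 log units; beyond the scatter), concerned a chain carbon and involved no ring, so this is the first sign that the number responds to the group attached directly to this nitrogen, and that a three-membered ring of carbon only is accepted there with a lower number than methyl. The exchange adds carbon and a ring while no hydrogen-bond donor or acceptor enters or leaves, and no measurement at hand accounts for the size of the step.

On these data alone, it remains open whether the lower number goes with the ring itself or simply with the added carbons, a question that ethyl, isopropyl or cyclobutyl on the same nitrogen would help to settle. As far as these compounds go, it is also open whether methylamino to cyclopropylamino gives a similar step when the benzyl ring carries fluorine instead of chlorine.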